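Fluoro for Hydroxy, Tried on a Second Core

The source may report more compounds than this note shows. Statements on the series, on what has been measured and on what is new or still open speak of the compounds shown alone.

Measured so far, in a functional assay on MIA PaCa-2 cells (Homo sapiens) for antiproliferative activity, read by sulforhodamine B assay, with a stated time of 48 h; a lower number here means a stronger inhibitor, a higher number a weaker inhibitor:
compound 1, `COc1ccc(C(=O)/C=C\Nc2ccc(-c3nc4cc(OC)c(OC)c(OC)c4s3)cc2C)cc1O`, gives 15400 nM
compound 2, `COc1ccc2nc(-c3ccc(N/C=C\C(=O)c4ccc(OC)c(O)c4)c(C)c3)sc2c1`, gives 17000 nM
compound 3, `COc1ccc(C(=O)/C=C\Nc2ccc(-c3nc4cc(OC)c(OC)c(OC)c4s3)cc2C)cc1F`, gives 1800 nM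

Compound 3 differs from compound 1 by one change, (fluoro in place of hydroxy on an aromatic carbon), and that change made a step of an 8.6-fold lower number from compound 1 to compound 3 (0.93 log units; beyond the scatter). Compound 2 carries a different core; how the two cores differ is not broken down here, and in this assay compound 2 and compound 1 give numbers that lie close together.

Compound 4, `COc1ccc2nc(-c3ccc(N/C=C\C(=O)c4ccc(OC)c(F)c4)c(C)c3)sc2c1`, is not yet measured. It differs from compound 2 by fluoro in place of hydroxy on an aromatic carbon, at the same place as before, so this is the same change. Compound 4 is expected to step by a 7.7-fold lower number from compound 2 to compound 4 (0.89 log units; beyond the scatter) from compound 2, set beside the earlier step, because from compound 1 to compound 3 the same change gave an 8.6-fold lower number from compound 1 to compound 3 (0.93 log units; beyond the scatter). The estimate for compound 4 is 2200 nM, expected between 800 nM and 7000 nM.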

Compound 4, half-maximal inhibitory concentration: 2300 nM
Beside the measured number, compound 4's estimate is 1.0-fold (0.02 log units) below it; low and high end bracket the measured number.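

Putting fluoro in place of hydroxy, which turns a 3-hydroxy-4-methoxyphenyl into a 3-fluoro-4-methoxyphenyl, gave a 7.4-fold lower number from compound 2 to compound 4 (0.87 log units; beyond the scatter) in this assay, so the fluoro compound is the stronger inhibitor of this pair. On the two cores shown, the change carried over with much the same size: the same change on two cores in this assay, an 8.6-fold lower number (0.93 log units; beyond the scatter) from compound 1 to compound 3 and a 7.4-fold lower number (0.87 log units; beyond the scatter) from compound 2 to compound 4, 1.2-fold (0.06 log units) apart, within the scatter of two such steps

These two pairs show that the step held on both cores in this one assay, but they do not say why it happens or whether it would hold on a third core.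

The compounds shown leave open how other groups at this place, such as chloro, an amine or a carboxylic acid, would compare with fluoro. Also open, as far as these compounds go, is whether the step would appear in other cell lines.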